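The source may report more compounds than this note shows. Statements on the series, on what has been measured and on what is new or still open speak of the compounds shown alone.

Measured so far in a functional assay on HCT-116 cells (Homo sapiens) for inhibition, read by MTT assay, with a stated time of 72 h; on this read-out lower numbers stand for stronger inhibition of growth and higher numbers for weaker inhibition of growth:
compound 1 `CC1=C(CCCCCCCCCCn2cc(C[C@H](O)COCCOC[C@@H](O)Cc3ccc(-c4ccccc4)cc3)nn2)C(=O)c2ccccc2C1=O` – 3000 nM
compound 2 `COC1=C(OC)C(=O)C(CCCCCCCCCCn2cc(C[C@H](O)COCCOC[C@@H](O)Cc3ccc(-c4ccccc4)cc3)nn2)=C(C)C1=O` – 600 nM
compound 3 `O[C@H](COCCOC[C@@H](O)Cc1cn(-c2cccs2)nn1)Cc1ccc(-c2ccccc2)cc1` – 33400 nM

Compound 3 gives the highest number of the three in this assay. Its nearest neighbour is compound 1, whose value is lower by a margin well beyond the scatter; compound 2 lies lower still. Going by the values given here, compounds 1 and 2 carry a long chain and a quinone on the triazole nitrogen and are not single-point neighbours of compound 3, so no step from them can be carried over.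

Compound 4 `O[C@H](COCCOC[C@@H](O)Cc1cn(-c2cncc3ccccc23)nn1)Cc1ccc(-c2ccccc2)cc1` differs from compound 3 in one place: isoquinolin-4-yl in place of thiophen-2-yl on an aromatic nitrogen. Among the compounds with values here, no measured pair shows what such a change does here. The expectation for compound 4 is therefore a step no larger than modest, with the direction uncertain and a slight lean toward a lower number, as a 1.7-fold lower number from compound 3 to compound 4 (0.22 log units; within the scatter). Compound 4 is estimated at 20000 nM, within a range of 5000 nM to 60000 nM.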

Compound 4, concentration for 50% growth inhibition: 17800 nM
Compound 4: middle estimate off by 1.1-fold (0.05 log units), on the high side; the range from low to high includes it.
By their numbers in this assay, from the lowest: compound 2; then compound 1; then compounds 4 and 3 (each within the scatter of the next).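

In this assay, isoquinolin-4-yl in place of thiophen-2-yl on an aromatic nitrogen gives a 1.9-fold lower number from compound 3 to compound 4 (0.27 log units; within the scatter), the first single-place step read in this series. At this position, on a five-membered aromatic ring with 3 nitrogen, a group of 10 heavy atoms with two aromatic rings therefore reads the same, within the scatter, as a group of 5 heavy atoms with one aromatic ring. No measured evidence on either group bears on this step.

The compounds shown leave open what a plain phenyl, or an aromatic ring carrying an amine or a carboxylic acid, would give on this nitrogen. Going by these compounds alone, no single-place step links compound 3 or compound 4 to compound 1 or compound 2, so the contributions of the long chain and the quinone remain unseparated.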